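The source may report more compounds than this note shows. Statements on the series, on what has been measured and on what is new or still open speak of the compounds shown alone.

Within the data shown here, compound 1 `Oc1ccc(-c2cc(-c3ccc(F)cc3)cc(-c3cccc(O)c3)n2)cc1` is the only member of this pair of measured compounds to give a number: in a functional assay on DU-145 cells (Homo sapiens) for inhibition (a higher number here means a weaker inhibitor, a lower number a stronger inhibitor), compound 1 gives 15200 nM. Compound 2 `Oc1ccc(-c2cc(-c3ccc(OC(F)(F)F)cc3)cc(-c3ccccc3O)n2)cc1` is a different matter. In this assay compound 2 reaches only a limit, > 50000 nM, and this is the assay limit rather than a measured number (the limit of > 50000 nM in this assay, at which 1 of the 2 values shown sits). Compound 3 `Oc1ccc(-c2cc(-c3ccc(OC(F)(F)F)cc3)cc(-c3cccc(O)c3)n2)cc1` keeps the same atoms as compound 2 but joins them differently: 3-hydroxyphenyl in place of 2-hydroxyphenyl on an aromatic carbon, so that compound 3 carries the same hydroxyphenyl arrangement as compound 1 while keeping the trifluoromethoxyphenyl group of compound 2. Since compound 2 sits at the limit and compound 1 gives a number, compound 3 is expected to move toward a measurable value, with the step from compound 2 to compound 3 estimated at an at least 2.2-fold lower number from compound 2 to compound 3 (0.35 log units; beyond the scatter). Compound 3 is accordingly expected to give about 22000 nM in this assay, within a range from 8000 nM to 50000 nM.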

Compound 3, half-maximal inhibitory concentration: 18100 nM
Estimate against measurement, compound 3: 1.2-fold (0.08 log units) above; the measured number falls inside the stated range.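

With the trifluoromethoxyphenyl group held constant, 3-hydroxyphenyl in place of 2-hydroxyphenyl next to the ring nitrogen gives, in this assay, an at least 2.7-fold lower number from compound 2 to compound 3 (0.44 log units; beyond the scatter), so the read-out at this position depends on where the hydroxyl stands on the phenyl ring. The full size of that step cannot be given, since compound 2 stands at a limit and not at a number: the limit of > 50000 nM in this assay, at which 1 of the 3 values shown sits.

With 3-hydroxyphenyl in place, trifluoromethoxy in place of fluoro gives a 1.2-fold higher number from compound 1 to compound 3 (0.08 log units; within the scatter), which leaves the two compounds level in this assay.

The compounds shown leave open whether an amine or a methoxy group in place of the hydroxyl on this ring would lower the number. They also leave open whether 2-hydroxyphenyl would behave the same way alongside the fluorophenyl group of compound 1.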